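Swapping benzyl for phenylsulfonyl on the chain of compound 3

The source may hold more compounds than are shown below. What is called first, only, known or untested is meant among the compounds shown, and "the series" means these compounds.

Measured in a functional assay (aorta) with Oryctolagus cuniculus as the target; on this read-out higher numbers stand for weaker binding and lower numbers for tighter binding:
compound 1 (`COc1cc(C(C)O)ccc1OCCCN1CCC(C(c2ccc(F)cc2)c2ccc(F)cc2)CC1`): 10 nM
compound 2 (`CC(=O)c1ccc(OCCCN2CCC(C(c3ccc(F)cc3)c3ccc(F)cc3)CC2)cc1`): 2.51 nM
compound 3 (`Fc1ccc(C(c2ccc(F)cc2)C2CCN(CCCCc3ccccc3)CC2)cc1`): 2.51 nM

Compound 3 (2.51 nM) shares the lowest number of the three with compound 2, and compound 1 stands higher. Compound 4 (`O=S(=O)(CCCN1CCC(C(c2ccc(F)cc2)c2ccc(F)cc2)CC1)c1ccccc1`) carries phenylsulfonyl in place of benzyl on a saturated chain carbon, three bonds along the chain from an amine nitrogen in a ring. For the measured compounds named here, no measured step makes this exact change. The nearest steps act at the same place, and they differ: one showed nothing beyond the scatter (no change at the digits printed from compound 2 to compound 3 (within the scatter)), the other was modest (a 4.0-fold lower number from compound 1 to compound 3 (0.60 log units; beyond the scatter)). A small rise is therefore expected in this assay, an estimated step (a 2.0-fold higher number from compound 3 to compound 4 (0.30 log units; within the scatter)). For compound 4 the expected value is 5 nM (estimated range 1.5 nM to 16 nM).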

Compound 4, dissociation constant: 20 nM
Beside the measured number, compound 4's estimate is 4.0-fold (0.60 log units) below it, outside the stated range (above it).
By their numbers in this assay, from the lowest: compounds 2 and 3 (each within the scatter of the next); then compounds 1 and 4 (each within the scatter of the next).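

At the saturated chain carbon, three bonds along the chain from an amine nitrogen in a ring, this assay now shows a rise beyond the scatter with phenylsulfonyl, both against benzyl (an 8.0-fold higher number from compound 3 to compound 4 (0.90 log units; beyond the scatter)) and against 4-acetylphenoxy (an 8.0-fold higher number from compound 2 to compound 4 (0.90 log units; beyond the scatter)). Those two groups had read alike (no change at the digits printed from compound 2 to compound 3 (within the scatter)), whereas phenylsulfonyl falls in with 4-(1-hydroxyethyl)-2-methoxyphenoxy (a 2.0-fold higher number from compound 1 to compound 4 (0.30 log units; within the scatter)), so compound 1 no longer stands alone above them. Nothing measured here accounts for this rise. Still open, as far as these compounds go, is how a sulfonamide or an amide would read at this place, and whether the rise holds with a longer chain.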